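A few compounds are considered here, and "the series" means these few. Any claim that something is new, unique, unknown or untested is made for them only; others in the source may bear on it.

Compound 2 `COC(=O)/C=C/c1cccc(N(Cc2ccc(/C=C/c3ccccc3F)cc2)C(=O)C2CCCCC2)c1` gives 64 nM in an assay on isolated protein with Bile acid receptor (Homo sapiens) as the target (a higher number here means that more compound is needed for the effect, a lower number that less compound is needed), the lowest of the three numbers shown. Compound 3 `COC(=O)/C=C/c1cccc(N(Cc2ccc(/C=C/c3ccccc3F)cc2)C(=O)NC(C)C)c1` gives 431 nM and compound 1 `COC(=O)/C=C/c1cccc(N(Cc2ccc(/C=C/c3cc(C(F)(F)F)cc(C(F)(F)F)c3)cc2)C(=O)C2CCCCC2)c1` gives 1470 nM. Going by the values given here, the only measured step, a 6.7-fold higher number from compound 2 to compound 3 (0.83 log units; beyond the scatter), concerns the group on the carbonyl carbon, not the aromatic end that changes in compound 4 `COC(=O)/C=C/c1cccc(N(Cc2ccc(-c3ccc(F)c(Cl)c3)cc2)C(=O)C2CCCCC2)c1`: 3-chloro-4-fluorophenyl in place of 2-(2-fluorophenyl)ethenyl on an aromatic carbon. Compound 1 and compound 2 differ at that same end, and their two values show a wide gap, but they are not a single-point pair. Among the compounds with values here, with no step bearing directly on this change, a modest rise is expected, a 3.1-fold higher number from compound 2 to compound 4 (0.49 log units; beyond the scatter). Compound 4 is therefore estimated at 200 nM, in a range from 50 nM to 800 nM.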

Compound 4, half-maximal effective concentration: 66 nM
Compound 4: the middle estimate sits 3.0-fold (0.48 log units) above what was measured; the range from low to high includes it.
By their numbers in this assay, from the lowest: compounds 2 and 4 (each within the scatter of the next); then compound 3; then compound 1.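

At this position, para to a large group, 3-chloro-4-fluorophenyl in place of 2-(2-fluorophenyl)ethenyl gives a 1.0-fold higher number from compound 2 to compound 4 (0.01 log units; within the scatter) in this assay. The double bond outside aromatic rings is therefore not required for a value in this range, at least with these two end groups, whereas compound 1 had left only a wide gap at this end and no single-point comparison. Nothing available explains this outcome. Going by these compounds, it remains open how an amine or a carboxylic acid on the phenyl ring would read, and whether the 3-chloro-4-fluorophenyl end would hold its value with isopropylamino in place of cyclohexyl on the carbonyl carbon.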